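Swapping the Carboxy Group: What Might Compound 4 Do?

The source may report more compounds than this note shows. Statements on the series, on what has been measured and on what is new or still open speak of the compounds shown alone.

Among the measured compounds shown here, in a functional assay (trachea) with Cavia porcellus as the target (a higher number here means that more compound is needed for the effect, a lower number that less compound is needed), compound 1 (`CCCn1c(=O)n(CC(=O)O)c(=O)c2[nH]cnc21`) gives 41000 nM as the highest of the three numbers so far, so it needs the most compound. Compound 2 (`CCCn1c(=O)n(CCC#N)c(=O)c2[nH]cnc21`) gives 1700 nM and compound 3 (`CCCn1c(=O)n(CCN(C)C)c(=O)c2[nH]cnc21`) gives 2700 nM as its reading. Between these two lies a 1.6-fold higher number from compound 2 to compound 3 (0.20 log units; within the scatter) and so neither can be ranked above the other.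

Compound 4 (`CCCn1c(=O)n(CCO)c(=O)c2[nH]cnc21`) has not been measured. It carries hydroxymethyl in place of carboxy on a saturated chain carbon bound to an aromatic nitrogen. For the measured compounds named here, two measured steps bear on this change, since both also remove the carboxy group from that carbon. Cyanomethyl gave a 24-fold lower number from compound 1 to compound 2 (1.38 log units; beyond the scatter) and (dimethylamino)methyl gave a 15-fold lower number from compound 1 to compound 3 (1.18 log units; beyond the scatter) as its result. Neither new group is hydroxymethyl, and two examples make only a thin basis, so the expectation is loose.

A large drop of similar size is still expected in this assay for this third replacement. The estimated change is a 16-fold lower number from compound 1 to compound 4 (1.21 log units; beyond the scatter) as the central case. Compound 4 is expected to read 2500 nM with an estimated range of 800 nM to 8000 nM as the likely spread.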

Compound 4, half-maximal effective concentration: 510 nM
Compound 4: middle estimate off by 4.9-fold (0.69 log units), on the high side; measured number outside the range, below it.
By their numbers in this assay, from the lowest: compound 4; then compounds 2 and 3 (each within the scatter of the next); then compound 1.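

Replacing carboxymethyl with 2-hydroxyethyl gives an 80-fold lower number from compound 1 to compound 4 (1.91 log units; beyond the scatter) in this assay, so all three replacements on a saturated chain carbon bound to an aromatic nitrogen now lower the number, and no compound shown goes against that. What is new is that the replacements are no longer interchangeable: the cyano and dimethylamino compounds could not be told apart, yet hydroxy gives a 3.3-fold lower number from compound 2 to compound 4 (0.52 log units; beyond the scatter) and a 5.3-fold lower number from compound 3 to compound 4 (0.72 log units; beyond the scatter) and both of these steps lie beyond the usual scatter. Losing the carboxy group therefore does not settle the outcome by itself, since the group that arrives in its place also matters, and compound 4 now needs the least compound of the four.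

The compounds shown leave open whether a methoxy group, a primary amine or a longer chain ending in hydroxy would keep, extend or lose this gain. Nothing available here explains why the number shifts as it does at this place.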